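The source may hold more compounds than are shown below. What is called first, only, known or untested is meant among the compounds shown, and "the series" means these compounds.

In a physicochemical assay for lipophilicity, using the shake flask method, measured as octanol-water partition, with a stated time of 30 min, at pH 7.4 (on this read-out lower numbers stand for lower lipophilicity and higher numbers for higher lipophilicity), the three measured compounds stand as follows:

Compound 1 `COCc1ccc(-c2ccc3nnc(C(N)=O)c(N[C@@H](C)c4ccn(C)n4)c3c2)cn1` gives 3.
Compound 2 `COCc1ccc(-c2ccc3nnc(C(N)=O)c(N[C@@H](C)c4nn(C)cc4C)c3c2)cn1` gives 2.8.
Compound 3 `C[C@H](Nc1c(C(N)=O)nnc2ccc(-c3ccc(OCCCN4CCCC4)nc3)cc12)c1ccn(C)n1` gives 1.8.

The change from compound 1 to compound 2 is methyl in place of hydrogen on an aromatic carbon, and it brought a number 0.20 log units lower from compound 1 to compound 2 (within the scatter). The two cores differ by 3-(pyrrolidin-1-yl)propoxy in place of methoxymethyl on an aromatic carbon, and that change brought a number 1.20 log units lower from compound 1 to compound 3 (beyond the scatter), leaving compound 3 with the lowest of the three numbers.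

Compound 4 `Cc1cn(C)nc1[C@H](C)Nc1c(C(N)=O)nnc2ccc(-c3ccc(OCCCN4CCCC4)nc3)cc12` has not yet been measured in this assay. It differs from compound 3 by methyl in place of hydrogen on an aromatic carbon, which is the same change as from compound 1 to compound 2, at a place described in the same words. The step from compound 3 to compound 4 is expected to be a number 0.20 log units lower from compound 3 to compound 4 (within the scatter), because the earlier instance of this change gave a number 0.20 log units lower from compound 1 to compound 2 (within the scatter). Compound 4 is therefore estimated at 1.6, with a likely range from 1.2 to 2.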

Compound 4, distribution coefficient: 2.1
Compound 4: the middle estimate sits 0.50 log units below what was measured, outside the stated range (above it).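

In this assay the change from 1-methyl-1H-pyrazol-3-yl to 1,4-dimethyl-1H-pyrazol-3-yl gave a number 0.20 log units lower from compound 1 to compound 2 (within the scatter) on one core and a number 0.30 log units higher from compound 3 to compound 4 (within the scatter) on the other. This shows that the methyl moved no number beyond the scatter on either core, but two pairs do not show that it is without effect elsewhere, and the opposite signs do not amount to a reversal. The 3-(pyrrolidin-1-yl)propoxy change gave a number 0.70 log units lower from compound 2 to compound 4 (beyond the scatter), in the same direction as a number 1.20 log units lower from compound 1 to compound 3 (beyond the scatter), and no further evidence bears on either result.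

The compounds shown leave open whether a longer chain such as ethyl in place of that methyl would also stay within the scatter. They also leave open how a morpholine in place of the pyrrolidine would read.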